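Trimming a sulfonamide to a sulfone on a shared core

The source may hold more compounds than are shown below. What is called first, only, known or untested is meant among the compounds shown, and "the series" means these compounds.

Of the compounds shown here, two have so far been tested in a functional assay on cells for antagonist activity at prostaglandin D2 receptor 2 (Homo sapiens), read by flow cytometry, with a stated time of 10 min; a lower number here means a stronger inhibitor, a higher number a weaker inhibitor. Compound 1 `CN(C)S(=O)(=O)c1ccc(F)c(C#Cc2cc(Cl)ccc2OCC(=O)O)c1` gives 23 nM in this assay. Compound 2 `Cc1ccc(S(=O)(=O)NC(C)C)cc1C#Cc1cc(Cl)ccc1OCC(=O)O` gives 250 nM in this assay. Among the measured compounds shown here, of these two numbers the one for compound 1 is the lower, and the gap to compound 2 lies beyond the usual scatter of repeated measurements, so compound 1 is the stronger inhibitor of the pair. Compound 2 differs from compound 1 in more than one place, so its value says nothing on its own about any single change.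

Compound 3 `CS(=O)(=O)c1ccc(F)c(C#Cc2cc(Cl)ccc2OCC(=O)O)c1` has not yet been measured. It arises from compound 1 by one change: methyl in place of dimethylamino on a sulfonyl sulfur. The core of compound 1 is kept unchanged. For the measured compounds named here, no measured pair shows this change alone, so its size cannot be read off from data. A small step is expected, if any, most likely slightly upward toward a weaker inhibitor, and possibly within the scatter. Compound 3 is therefore estimated to give 45 nM in this assay, within a range from 12 nM to 170 nM. This estimate corresponds to an expected step of a 2.0-fold higher number from compound 1 to compound 3 (0.29 log units; within the scatter) in this assay.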

Compound 3, half-maximal inhibitory concentration: 95 nM
The estimate for compound 3 lay 2.1-fold (0.32 log units) below the measured number, and the stated range covers the measured number.
By their numbers in this assay, from the lowest: compound 1; then compound 3; then compound 2.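

In this assay, putting methyl in place of dimethylamino on the sulfonyl sulfur gives a 4.1-fold higher number from compound 1 to compound 3 (0.62 log units; beyond the scatter). Among the compounds shown here, this is the first direct reading of a single change at this position, and it shows that the group on the sulfur matters: the step lies beyond the usual scatter, with the dimethylsulfamoyl compound the stronger inhibitor of this pair. The step is modest, however, and compound 3 still gives 95 nM, so inhibition in the nanomolar range does not depend on keeping the dimethylamino group, and no measurement at hand explains the change in potency.

For the compounds shown here, because this step swaps one group for another in a single move, it cannot show whether the nitrogen or the extra carbon counts for more, and the same change on the sulfonyl sulfur has been read on only this one core. An unsubstituted amino group, a methylamino group, an ethyl group or a pyrrolidine ring on the same sulfur would help separate these possibilities.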